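This account rests on a few compounds, and the source may have more. Where it says the series, first, only, none or still open, it means among the compounds named here.

Compound 1 `COc1cccc(-n2cc(NC(=O)c3cccc(NS(=O)(=O)c4ccccc4)c3)cn2)c1` carries a phenylsulfonyl group on the ring that bears the amide. In a functional assay on A549 cells (Homo sapiens) for inhibition, read by MTT assay, with a stated time of 48 h (on this read-out lower numbers stand for stronger inhibition and higher numbers for weaker inhibition), compound 1 gives 81100 nM. Compound 2 `COc1cccc(-n2cc(NC(=O)c3cccc(NS(=O)(=O)c4ccc(Cl)cc4)c3)cn2)c1` differs from compound 1 only by chloro in place of hydrogen on an aromatic carbon, and in this assay compound 2 gives 44400 nM. That change produced a 1.8-fold lower number from compound 1 to compound 2 (0.26 log units; within the scatter), so the two numbers cannot be told apart with confidence. Compound 3 `Cc1ccc(-n2cc(NC(=O)c3ccc(NS(=O)(=O)c4ccccc4)cc3)cn2)cc1` is built on a different core; the difference between the two cores is not broken down here. In this assay compound 3 gives 54700 nM, a number that sits within the scatter of both compound 1 and compound 2.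

Compound 4 `Cc1ccc(-n2cc(NC(=O)c3ccc(NS(=O)(=O)c4ccc(Cl)cc4)cc3)cn2)cc1` has not yet been measured. It differs from compound 3 by chloro in place of hydrogen on an aromatic carbon, the same change, made at the same kind of place, that separates compound 2 from compound 1. Because a 1.8-fold lower number from compound 1 to compound 2 (0.26 log units; within the scatter) was small, compound 4 is expected to give about 33000 nM, which would be a step of a 1.7-fold lower number from compound 3 to compound 4 (0.22 log units; within the scatter), with a plausible range from 15000 nM to 70000 nM. This expectation rests on a single earlier example and is therefore uncertain.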

Compound 4, half-maximal inhibitory concentration: 22000 nM
The estimate for compound 4 lay 1.5-fold (0.18 log units) above the measured number; the range from low to high includes it.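

Chloro in place of hydrogen, which turns phenylsulfonyl into (4-chlorophenyl)sulfonyl, gives a 2.5-fold lower number from compound 3 to compound 4 (0.40 log units; beyond the scatter) in this assay, a modest step that lies beyond the usual scatter. Set beside the earlier pair, this step cannot be told apart in size from the one on the other core: the same change on two cores in this assay, a 1.8-fold lower number (0.26 log units; within the scatter) from compound 1 to compound 2 and a 2.5-fold lower number (0.40 log units; beyond the scatter) from compound 3 to compound 4, 1.4-fold (0.13 log units) apart, within the scatter of two such steps. The result is consistent with the change carrying over between these two cores, but the earlier step cannot be separated from scatter on its own, and two pairs in one cell assay show neither why the number falls nor that the same would happen on a further core.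

The compounds shown leave open whether a different group at the same place on the ring, such as fluoro, methoxy or trifluoromethyl, would give a lower number than chloro. They also leave open how an amine or a carboxylic acid at that place would read out on either core.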